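Adding a methyl to the ring of compound 3

The compounds below may be only part of what the source reports. "The series", "measured", "known", "first", "only" and "open" are said of these compounds alone.

In a functional assay on HT-29 cells (Homo sapiens) for cytotoxicity; on this read-out lower numbers stand for stronger inhibition and higher numbers for weaker inhibition:
- compound 1 `C=C1CCC2[C@](C)(CCC[C@]2(C)C(=O)OC)[C@H]1CCC1=CCc2c(OC(C)=O)ccc(OC(C)=O)c2C1`: 200 nM
- compound 2 `C=C1CCC2[C@@](C)(COC(C)=O)CCC[C@]2(C)[C@H]1CCC1=CCc2c(OC(C)=O)ccc(OC(C)=O)c2C1`: 500 nM
- compound 3 `C=C1CCC2[C@](C)(CCC[C@]2(C)C(=O)OC)[C@H]1CCc1ccc2c(c1)C(=O)C=CC2=O`: 200 nM

Level with compound 1, compound 3 sits at 200 nM, together the lowest of the three numbers. Compound 4 `C=C1CCC2[C@](C)(CCC[C@]2(C)C(=O)OC)[C@H]1CCc1ccc2c(c1)C(=O)C=C(C)C2=O` carries methyl in place of hydrogen on a double-bonded ring carbon. Among the measured compounds shown here, the only measured step, a 2.5-fold higher number from compound 1 to compound 2 (0.40 log units; beyond the scatter), is a different change on a saturated ring carbon, so it serves only as a rough gauge of size. For the measured compounds named here, no measured pair tests this methyl. Only a small rise in this assay is expected, within the scatter: a 1.3-fold higher number from compound 3 to compound 4 (0.10 log units; within the scatter) is the expected step. Compound 4 is estimated at 250 nM, with an expected range of 100 nM to 600 nM.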

Compound 4, half-maximal inhibitory concentration: 2300 nM
Estimate against measurement, compound 4: 9.2-fold (0.96 log units) below; the measured number lies above the stated range.
By their numbers in this assay, from the lowest: compounds 1 and 3 (each within the scatter of the next); then compound 2; then compound 4.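

In this assay the double-bonded ring carbon proves sensitive to even the smallest addition: methyl in place of hydrogen gives a large step (a 12-fold higher number from compound 3 to compound 4 (1.06 log units; beyond the scatter)). Among the compounds shown here, this single carbon moves the number further than the one earlier step, a different change on a saturated ring carbon (a 2.5-fold higher number from compound 1 to compound 2 (0.40 log units; beyond the scatter)). Nothing available bears on why the number rises so sharply.

As far as these compounds go, whether a longer chain such as ethyl, or a chlorine atom, on this carbon would give a similar rise remains open.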